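The source may report more compounds than this note shows. Statements on the series, on what has been measured and on what is new or still open speak of the compounds shown alone.

Measured compounds:
- compound 1, `O=S(=O)(CC1=NCCS1)C1=NNCC1c1ccccc1`, "not active" (no number reported) in a functional assay, tested at 50 ug/mL; a lower number here means a weaker effect, a higher number a stronger effect of the compound at the concentration tested
- compound 2, `O=S(=O)(CC1=NCCO1)C1C(c2ccc(Cl)cc2)=NN(c2ccccc2)C1c1ccc(Cl)cc1`, "not active" (no number reported) in this assay
- compound 3, `COc1ccc(-c2nn(-c3ccccc3)c(-c3ccc(C)cc3)c2S(=O)(=O)CC2=NCCO2)cc1`, 67.6% in this assay

Compound 1 stands without a number: in this assay compound 1 is reported as inactive only. The same holds for compound 2, which in this assay gives "not active" (no number reported) and nothing more. Compound 3 is the only one of the three with a figure; in this assay compound 3 gives 67.6%. Going by the values given here, compound 3 differs from compound 1 in many places at once, so no single step between them is counted, and their two values show only that one of the three compounds reaches a measurable effect while the other two do not.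

Compound 4, `O=S(=O)(CC1=NCCS1)C1=NNCC1c1ccc(Cl)cc1`, has not yet been tested. It differs from compound 1 in one place: chloro in place of hydrogen on an aromatic carbon. No step between measured compounds of this kind is shown, so there is no counted guide for its size. Since compound 1 is reported inactive, the expectation for this step is a small one, in no direction beyond the scatter, with a further inactive report as the most likely outcome. Compound 4 is therefore estimated at 12% in this assay, within a range from 0% to 40%.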

Compound 4, a percentage reported as activity, at one concentration (the size of the read-out at that concentration, not a potency): "not active" (no number reported)
Nothing numeric was reported for compound 4; no gap can be computed for the estimate.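

In this assay compound 1 and compound 4 are both reported only as inactive, so no step can be read for the change from phenyl to 4-chlorophenyl. No further measurement here bears on this result. Still open, on these data alone, is whether chloro in place of hydrogen changes the effect in a compound with a measurable read-out, such as compound 3 (67.6%).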